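The source may hold more compounds than are shown below. What is called first, only, known or untested is meant among the compounds shown, and "the series" means these compounds.

Measured so far in a functional assay on A549 cells (Homo sapiens) for cytotoxicity, read by WST assay, with a stated time of 72 h; a lower number here means a stronger inhibitor, a higher number a weaker inhibitor:
compound 1 `COc1cc2c(Nc3nc4ccc(C(=O)Nc5c(C)cc(C)cc5C)cc4s3)ncnc2cc1OCCCN1CCC(C)CC1` gives 5400 nM
compound 2 `COc1cc2c(Nc3nc4ccc(C(=O)Nc5c(C)cc(C)cc5C)cc4s3)ncnc2cc1OCCCN1CCCCC1C` gives 5800 nM
compound 3 `COc1cc2c(Nc3nc4ccc(C(=O)Nc5c(C)cccc5Cl)cc4s3)ncnc2cc1OCCCN1CCCC1` gives 38600 nM

Compound 3 holds the highest of the three numbers in this assay, beyond the scatter from both compound 1 and compound 2. Compound 4 `COc1cc2c(Nc3nc4ccc(C(=O)Nc5c(C)cc(C)cc5C)cc4s3)ncnc2cc1OCCCN1CCCC1` arises from compound 3 by 2,4,6-trimethylphenyl in place of 2-chloro-6-methylphenyl on an amide-type nitrogen; the amide aryl of compound 4 is that of compounds 1 and 2, while its amine is that of compound 3. Within the data shown here, no measured step covers this aryl exchange. Among the measured compounds shown here, the one measured step, a 1.1-fold higher number from compound 1 to compound 2 (0.03 log units; within the scatter), shows only that an amine change of this kind hardly moves the number. On the gap between compound 3 and compounds 1 and 2, compound 4 is expected to give a lower number, a step of a 5.5-fold lower number from compound 3 to compound 4 (0.74 log units; beyond the scatter). Compound 4 is estimated at 7000 nM, between 2500 nM and 20000 nM.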

Compound 4, half-maximal inhibitory concentration: 8900 nM
For compound 4 the middle estimate is 1.3-fold (0.10 log units) below the measured one; low and high end bracket the measured number.
By their numbers in this assay, from the lowest: compounds 1, 2 and 4 (each within the scatter of the next); then compound 3.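

In this assay, with pyrrolidin-1-yl held fixed, 2,4,6-trimethylphenyl in place of 2-chloro-6-methylphenyl on an amide-type nitrogen gives a 4.3-fold lower number from compound 3 to compound 4 (0.64 log units; beyond the scatter) and so places the earlier gap at the amide aryl. With 2,4,6-trimethylphenyl held fixed, the amine exchanges give a 1.5-fold higher number from compound 2 to compound 4 (0.19 log units; within the scatter) and a 1.6-fold higher number from compound 1 to compound 4 (0.22 log units; within the scatter) and both stay within the scatter. Nothing measured explains the aryl step.

Still open, on these data alone, is whether unsubstituted phenyl or 2,6-dichlorophenyl on the amide nitrogen would match 2,4,6-trimethylphenyl. Also open, as far as these compounds go, is whether morpholin-4-yl in place of the amine would stay within the scatter.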